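Acetyl for Cyano at the Limit of Detection

This account rests on a few compounds, and the source may have more. Where it says the series, first, only, none or still open, it means among the compounds named here.

The study reads an assay on isolated protein for inhibition of inhibitor of nuclear factor kappa-B kinase subunit epsilon (Homo sapiens), read by mobility shift assay (on this read-out lower numbers stand for stronger inhibition and higher numbers for weaker inhibition), on two compounds of a shared core. Compound 1 `COc1ccc(-c2nc3c(NCCCNC(=O)C4CCCC4)c(C(N)=S)cnc3[nH]2)cc1` gives 448 nM in this assay. For compound 2 `COc1ccc(-c2nc3cc(-c4csc(C#N)c4)cnc3[nH]2)cc1` this assay reports only a limit, > 30000 nM, and not a number. That value is the limit of > 30000 nM in this assay, at which 1 of the 2 values shown sits, so the standing of compound 2 is known only as lying at that limit.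

Compound 3 `COc1ccc(-c2nc3cc(-c4csc(C(C)=O)c4)cnc3[nH]2)cc1` has not yet been measured. It differs from compound 2 in one place: acetyl in place of cyano on an aromatic carbon, in words acetyl in place of cyano on an aromatic carbon. Among the measured compounds shown here, no step between measured compounds exists to size this change. Because compound 2 sits at > 30000 nM, the account expects compound 3 to remain weak in this assay, with no change beyond the usual scatter and a fair chance that only a limit is reported again. Compound 3 is therefore estimated at 25000 nM, in a range from 5000 nM to 100000 nM, an expected step of an at least 1.2-fold lower number from compound 2 to compound 3 (0.07 log units; that floor lies within the scatter).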

Compound 3, half-maximal inhibitory concentration: 6750 nM
Compound 3: middle estimate off by 3.7-fold (0.57 log units), on the high side; measured number inside the range.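

In this assay, the place next to the ring sulfur proves responsive: acetyl in place of cyano on this aromatic carbon gives an at least 4.4-fold lower number from compound 2 to compound 3 (0.64 log units; beyond the scatter), so the change yields a measured number where there was previously only a limit. The size of this step is only a lower bound because compound 2 is reported as a limit and not a number: the limit of > 30000 nM in this assay, at which 1 of the 3 values shown sits. The entering and leaving groups carry the same printed count of hydrogen-bond acceptors and no donors, so that count alone does not separate them.

The compounds shown hold only these two groups at this position, and the reason for the step stays open. Whether an amine, a carboxylic acid or a longer acyl chain in the same place would lower the number further also remains untold.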